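The compounds below may be only part of what the source reports. "The series", "measured", "known", "first", "only" and "open" are said of these compounds alone.

Compound 1, `Cc1nc(S(C)(=O)=O)ccc1Oc1ncnc(OC2CCN(C(=O)OC3CCC3)CC2)c1F`: 13.6 nM
Compound 2, `Cc1nc(S(C)(=O)=O)ccc1Oc1ncnc(OC2CCN(C(=O)OC3(C(F)(F)F)CCC3)CC2)c1F`: 14.3 nM
Compound 3, `Cc1nc(S(C)(=O)=O)ccc1Oc1ncnc(OC2CCN(C(=S)OC(C)C)CC2)c1F`: 69.9 nM

In a functional assay on isolated protein for inhibition of Glucose-dependent insulinotropic receptor (Homo sapiens), read by HTRF and cAMP accumulation (a higher number here means that more compound is needed for the effect, a lower number that less compound is needed), compound 1 gives 13.6 nM, the lowest of the three numbers. Compound 2 lies closest (a 1.1-fold higher number from compound 1 to compound 2 (0.02 log units; within the scatter)), so the two cannot be ordered. Compound 3 lies furthest (a 5.1-fold higher number from compound 1 to compound 3 (0.71 log units; beyond the scatter)), and the same group also separates compound 2 from compound 3 (a 4.9-fold higher number from compound 2 to compound 3 (0.69 log units; beyond the scatter)).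

Compound 4, `Cc1nc(S(C)(=O)=O)ccc1Oc1ncnc(OC2CCN(C(=O)C(F)(F)F)CC2)c1F`, has not yet been measured. Relative to compound 1 the change is trifluoromethyl in place of cyclobutyloxy on a carbonyl carbon.

Two kinds of step bear on this. The trifluoromethyl added on a saturated ring carbon from compound 1 to compound 2 left the number unchanged within the scatter, which shows that a trifluoromethyl as such is tolerated in this region. The exchange of the whole group on the amine nitrogen in the ring, from compound 1 to compound 3 and from compound 2 to compound 3, cost a modest amount each time. Compound 4 removes the cyclobutyloxy altogether and puts trifluoromethyl directly on the carbonyl carbon, a larger departure from compound 1 than either measured step, so a modest rise in this assay is expected, in the direction of compound 3, with wide uncertainty.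

The expected step is a 2.9-fold higher number from compound 1 to compound 4 (0.47 log units; beyond the scatter). Compound 4 is estimated at 40 nM, with a range from 14 nM to 120 nM.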

Compound 4, half-maximal effective concentration: 151 nM
Compound 4: the middle estimate sits 3.8-fold (0.58 log units) below what was measured, outside the stated range (above it).
By their numbers in this assay, from the lowest: compounds 1 and 2 (each within the scatter of the next); then compound 3; then compound 4.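

In this assay, trifluoromethyl does not stand in for cyclobutyloxy on a carbonyl carbon: the change gives an 11-fold higher number from compound 1 to compound 4 (1.05 log units; beyond the scatter) and, with the trifluoromethyl-bearing ring of compound 2 as the starting point, an 11-fold higher number from compound 2 to compound 4 (1.02 log units; beyond the scatter) as the corresponding large step. The tolerance of trifluoromethyl on the saturated ring carbon of compound 2 therefore does not extend to trifluoromethyl directly on the carbonyl carbon, and the group on the amine nitrogen in the ring spans a wider range than compound 3 alone showed, with a 2.2-fold higher number from compound 3 to compound 4 (0.33 log units; beyond the scatter) as a further modest step. Nothing measured on these compounds accounts for the rise.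

The compounds shown leave open whether the result follows from losing the oxygen, losing the four-membered ring or gaining the trifluoromethyl: all three differ together between compound 1 and compound 4. A cyclobutyl, a methyl or a 2,2,2-trifluoroethoxy on the carbonyl carbon would separate these contributions.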